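Aryl swap at the benzylic ring: compound 3 to compound 4

The source may report more compounds than this note shows. Statements on the series, on what has been measured and on what is new or still open speak of the compounds shown alone.

Three compounds of the series share a core, with the amine bearing a benzyl group that carries different substituents. Compound 1 `FC(F)(F)c1ccccc1-c1nc(NCc2ccccc2)c2ccccc2n1` has hydrogen at that position and gives 3100 nM in an assay on a protein complex for inhibition of ubiquitin carboxyl-terminal hydrolase 1/WD repeat-containing protein 48 (Homo sapiens), read by fluorescence; a lower number here means a stronger inhibitor, a higher number a weaker inhibitor. Compound 2 `FC(F)(F)c1ccccc1-c1nc(NCc2ccc(-c3ccccc3)cc2)c2ccccc2n1` carries a phenyl there and gives 3700 nM. Compound 3 `FC(F)(F)c1ccccc1-c1nc(NCc2ccc(-c3cccc(Cl)c3)cc2)c2ccccc2n1` carries a 3-chlorophenyl and gives 2700 nM. The steps of a 1.2-fold higher number from compound 1 to compound 2 (0.08 log units; within the scatter), a 1.1-fold lower number from compound 1 to compound 3 (0.06 log units; within the scatter) and a 1.4-fold lower number from compound 2 to compound 3 (0.14 log units; within the scatter) are all within the scatter, so compound 3 sits in the same band as compound 1 and compound 2; no ordering among the three can be claimed.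

Compound 4 `FC(F)(F)c1cc(-c2ccc(CNc3nc(-c4ccccc4C(F)(F)F)nc4ccccc34)cc2)ccn1` is the next member. The change is 2-(trifluoromethyl)pyridin-4-yl in place of 3-chlorophenyl on an aromatic carbon, on an aromatic carbon of a six-membered aromatic ring of carbon only, para to a large group. Going by the values given here, the steps that bear on it are those at the same position: attaching phenyl, attaching 3-chlorophenyl, and adding chloro to the phenyl all left this assay unchanged beyond the scatter. The expectation is therefore a step of no more than the scatter in this assay, in either direction, giving an estimated 1.0-fold higher number from compound 3 to compound 4 (0.02 log units; within the scatter). Compound 4 is thus expected at 2800 nM, with a range from 1200 nM to 6500 nM.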

Compound 4, half-maximal inhibitory concentration: 4900 nM
The estimate for compound 4 lay 1.8-fold (0.24 log units) below the measured number, within the range that was stated.
By their numbers in this assay, from the lowest: compounds 3, 1, 2 and 4 (each within the scatter of the next).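

In this assay, going by these compounds alone, the aromatic carbon para to a large group now carries a ring with a hetero atom and a trifluoromethyl group, yet the swap of 3-chlorophenyl for 2-(trifluoromethyl)pyridin-4-yl gives a 1.8-fold higher number from compound 3 to compound 4 (0.26 log units; within the scatter) and leaves compound 4 in the same band as the earlier compounds. Against the phenyl of the earlier series the swap gives a 1.3-fold higher number from compound 2 to compound 4 (0.12 log units; within the scatter) and against the bare benzyl group it gives a 1.6-fold higher number from compound 1 to compound 4 (0.20 log units; within the scatter), so all four substituents at this position, including the one with a hydrogen-bond acceptor, remain indistinguishable in this assay. Within the data shown here, the series therefore shows no handle at this position so far, and no measurement available here accounts for these steps.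

The swap changes the ring atom and the trifluoromethyl group together, so a plain pyridin-4-yl or a 3-(trifluoromethyl)phenyl would be needed to separate the two. Also open, on these data alone, is whether a quite different group at this position, such as an amine or a carboxylic acid on the attached ring, would produce a step beyond the scatter.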